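Thiadiazole aryl swap in Mythimna separata activity

The source may hold more compounds than are shown below. What is called first, only, known or untested is meant among the compounds shown, and "the series" means these compounds.

Measured compounds:
compound 1 `CC(C)(C)n1ncc(OCc2nnc(-c3cc(F)c(Cl)cc3Cl)s2)c(Cl)c1=O`: 67100 nM
compound 2 `Cc1nnc(COc2cnn(C(C)(C)C)c(=O)c2Cl)o1`: > 299000 nM
compound 3 `Cc1cccc(-c2nnc(COc3cnn(C(C)(C)C)c(=O)c3Cl)o2)c1`: 116000 nM

In a functional assay on the whole organism for inhibition, with Mythimna separata as the target, with a stated time of 5 days (on this read-out higher numbers stand for an effect only at larger amounts of compound and lower numbers for an effect already at smaller amounts), compound 1 gives 67100 nM. Compound 3 gives 116000 nM in this assay, and the two values sit within the scatter of one another, so no order between them can be read. Compound 2 reports only a limit in this assay, namely > 299000 nM (the limit of > 299000 nM in this assay, at which 1 of the 3 values shown sits). Among the measured compounds shown here, the one measured step on this shared core, an at least 2.5-fold lower number from compound 2 to compound 3 (0.41 log units; beyond the scatter), shows that a 3-methylphenyl in place of a methyl improves the read-out at least modestly.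

Compound 4 `Cc1cccc(-c2nnc(COc3cnn(C(C)(C)C)c(=O)c3Cl)s2)c1` has not yet been measured. It arises from compound 1 by the change (3-methylphenyl in place of 2,4-dichloro-5-fluorophenyl on an aromatic carbon). For the measured compounds named here, no measured step covers this swap of one aryl group for another, and compound 3, which also carries 3-methylphenyl, differs from compound 4 in its five-membered ring, so its value can only be taken as a rough neighbour. Compound 1 and compound 3 lie close together, so the aryl exchange is expected to move the number little. Compound 4 is therefore expected to give about 95000 nM in this assay, between 35000 nM and 260000 nM, an estimated step of a 1.4-fold higher number from compound 1 to compound 4 (0.15 log units; within the scatter).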

Compound 4, half-maximal effective concentration: > 299000 nM
Compound 4 ended at the assay's limit; the forecaster's own chance of this, stated with the estimate: 25%; at least 3.1-fold (0.49 log units) between middle value and limit.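

On the aromatic carbon of the five-membered aromatic ring with 2 nitrogen and 1 sulfur, one aryl group cannot simply stand in for another in this assay: replacing 2,4-dichloro-5-fluorophenyl with 3-methylphenyl gives an at least 4.4-fold higher number from compound 1 to compound 4 (0.64 log units; beyond the scatter). The earlier step, an at least 2.5-fold lower number from compound 2 to compound 3 (0.41 log units; beyond the scatter), showed only that 3-methylphenyl reads better than methyl on the core shared by those two compounds, whereas this one shows that the identity of the aryl group also counts. Compound 4 reports only a limit and not a number, so the full size of the step stays unknown: the limit of > 299000 nM in this assay, at which 2 of the 4 values shown sit.

The exchange removes two chlorines and a fluorine and adds a methyl in a single move, so the compounds shown cannot tell which of these changes accounts for the step. As far as these compounds go, how a plain phenyl, a single chlorine on the phenyl or an amine on this carbon would read remains open, as does whether the same order of these two aryl groups would hold on the core of compound 3.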